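A Furan Ring in Place of Pyridine on the Shared Core

The compounds below may be only part of what the source reports. "The series", "measured", "known", "first", "only" and "open" are said of these compounds alone.

Compound 1 has the structure `c1ccc(-c2ccncc2)c(OCC2=NCCN2)c1`. It was tested in a functional assay for activation of Alpha-1A adrenergic receptor (Homo sapiens), read by calcium flux; on this read-out lower numbers stand for an effect already at smaller amounts and higher numbers for an effect only at larger amounts of compound. In this assay compound 1 gives < 100000 nM, which is a limit of the assay rather than a measured number. Compound 2, with the structure `Cc1cccnc1-c1ccccc1OCC1=NCCN1`, also reaches only a limit of < 100000 nM in this assay. Compound 3, `Cc1ccnc(-c2ccccc2OCC2=NCCN2)c1`, likewise stops at a limit of < 100000 nM in this assay. Within the data shown here, all three results therefore sit at the limit of < 100000 nM in this assay, at which 3 of the 3 values shown sit, so no ordering among them can be read and no step between measured compounds is available.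

Compound 4, `c1coc(-c2ccccc2OCC2=NCCN2)c1`, is still to be measured. It differs from compound 1 by furan-2-yl in place of pyridin-4-yl on an aromatic carbon. With every known value being a limit, the change from compound 1 to compound 4 is expected to show no step beyond the scatter, and the step that the limit leaves unreadable from compound 1 to compound 4 is my estimate of that. For compound 4 in this assay I estimate 40000 nM, expected between 5000 nM and 100000 nM, with a limit the most likely outcome.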

Compound 4, half-maximal effective concentration: 1.26 nM
The estimate for compound 4 lay 32000-fold (4.50 log units) above the measured number; the whole stated range lies above it.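

No size can be given for the change from compound 1 to compound 4, since compound 1 has only a limit and not a number: the limit of < 100000 nM in this assay, at which 3 of the 4 values shown sit. The compounds shown leave open whether other five-membered aromatic rings on the shared core would behave like furan-2-yl.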